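Swapping the anilino ring of an imidazopyrazine kinase inhibitor

This account rests on a few compounds, and the source may have more. Where it says the series, first, only, none or still open, it means among the compounds named here.

Measured compounds:
- compound 1, `Cc1n[nH]c2ccc(-c3nc4cnc(N5CCN(C)CC5)cn4c3Nc3ccccc3Cl)cc12`: "not determined" (no result reported)
- compound 2, `Cc1n[nH]c2ccc(-c3nc4cnc(N5CCN(C)CC5)cn4c3Nc3ccc(F)cc3Br)cc12`: 3830 nM
- compound 3, `COc1ccc(Nc2c(-c3ccc4[nH]nc(C)c4c3)nc3cnc(N4CCN(C)CC4)cn23)cc1OC`: "not determined" (no result reported)

All three share one core and differ only in the ring attached to the nitrogen that hangs off it. In a functional assay on MV4-11 cells (Homo sapiens) for inhibition, with a stated time of 120 h (on this read-out lower numbers stand for stronger inhibition and higher numbers for weaker inhibition), compound 1 has no result at all, and compound 3 likewise gives "not determined" (no result reported) in this assay, so compound 1 cannot be placed among the others by a number. For the measured compounds named here, the only value in hand is that of compound 2, which in this assay reaches 3830 nM, a weak result.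

Compound 4, `Cc1n[nH]c2ccc(-c3nc4cnc(N5CCN(C)CC5)cn4c3Nc3ccc(F)c(Cl)c3)cc12`, is the next variation on compound 1. It differs by 3-chloro-4-fluorophenyl in place of 2-chlorophenyl on a nitrogen on an aromatic ring. Going by the values given here, since no measured pair shows what this change does, the size of its step in this assay cannot be read off; the expectation is a modest shift, in either direction or none beyond the scatter, staying in the weak range that compound 2 occupies. Compound 4 is therefore expected to give about 3000 nM, most likely between 700 nM and 12000 nM.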

Compound 4, half-maximal inhibitory concentration: 2850 nM
Compound 4: middle estimate off by 1.1-fold (0.02 log units), on the high side; low and high end bracket the measured number.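

In this assay, putting 3-chloro-4-fluorophenyl in place of 2-bromo-4-fluorophenyl on the nitrogen gives a 1.3-fold lower number from compound 2 to compound 4 (0.13 log units; within the scatter) and leaves the two rings indistinguishable on this read-out. For the compounds shown here, this is the first pair with numbers at this position, and it shows that exchanging one halogen-bearing phenyl ring for another can leave the result within the scatter, with both compounds in the weak range. Nothing given here accounts for this result.

Neither compound 1 nor compound 3 has a number, and the steps to them cannot be read. Also open, from the compounds shown here alone, is whether a phenyl ring carrying an amine or a carboxylic acid in place of these halogens would move the number on this read-out beyond the scatter.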